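This account rests on a few compounds, and the source may have more. Where it says the series, first, only, none or still open, it means among the compounds named here.

In a functional assay on J774.A1 cells (Mus musculus) for inhibition, read by Griess assay, with stated times of 1 h and 24 h (a lower number here means a stronger inhibitor, a higher number a weaker inhibitor), compound 1 (`CCCOc1ccccc1C1CC(=O)c2ccccc2O1`) gives 44600 nM and compound 2 (`CC(C)c1ccc(COc2ccccc2C2CC(=O)c3ccccc3O2)cc1`) gives 28600 nM while compound 3 (`CCCCOc1ccccc1C1CC(=O)c2ccccc2O1`) gives 47700 nM and so stands within the scatter of both. Compound 4 (`CCOc1ccccc1C1CC(=O)c2ccccc2O1`) differs from compound 3 by hydrogen in place of ethyl on a saturated chain carbon, two bonds along the chain from an oxygen on an aromatic ring as hydrogen in place of ethyl on a saturated chain carbon, two bonds along the chain from an oxygen on an aromatic ring, which reads butoxy to ethoxy. The nearest measured change on this chain (a 1.1-fold higher number from compound 1 to compound 3 (0.03 log units; within the scatter)) stays within the scatter, as do the other two steps (a 1.6-fold lower number from compound 1 to compound 2 (0.19 log units; within the scatter) and a 1.7-fold higher number from compound 2 to compound 3 (0.22 log units; within the scatter)). No step beyond the scatter is therefore expected in this assay and no firm direction, the estimated step being (a 1.1-fold lower number from compound 3 to compound 4 (0.03 log units; within the scatter)). Compound 4 is expected at 45000 nM within an estimated range (25000 nM to 80000 nM).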

Compound 4, half-maximal inhibitory concentration: 38800 nM
Beside the measured number, compound 4's estimate is 1.2-fold (0.06 log units) above it; low and high end bracket the measured number.
By their numbers in this assay, from the lowest: compounds 2, 4, 1 and 3 (each within the scatter of the next).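

In this assay, the cut from butoxy to ethoxy gives a 1.2-fold lower number from compound 3 to compound 4 (0.09 log units; within the scatter) and the shorter cut on the same chain gives a 1.1-fold lower number from compound 1 to compound 4 (0.06 log units; within the scatter), so chain length from ethyl to butyl on this oxygen does not separate these compounds. The 4-isopropylphenyl group against methyl on the saturated chain carbon bound to an oxygen on an aromatic ring gives a 1.4-fold higher number from compound 2 to compound 4 (0.13 log units; within the scatter) and likewise does not separate them. Nothing available explains this flat result.

As far as these compounds go, whether an amine, a carboxylic acid or a chain longer than butyl at this position would give a step beyond the scatter remains open.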